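Methoxy epimer in a dichlorostyryl lactol series

This account rests on a few compounds, and the source may have more. Where it says the series, first, only, none or still open, it means among the compounds named here.

Compound 1 `CO[C@H]1C[C@H](O)C[C@@H](/C=C/c2ccc(Cl)cc2Cl)O1` sits at the bottom of a small set in an assay for inhibition of 3-hydroxy-3-methylglutaryl-coenzyme A reductase (Rattus norvegicus), tested at 2 ug/mL; a lower number here means a weaker effect, a higher number a stronger effect of the compound at the concentration tested: compound 1 gives 0%, level at the digits shown with compound 2 `COC(/C=C/c1ccc(Cl)cc1Cl)CC(O)CC(=O)O`, which gives 0%. The lactone compound 3 `O=C1C[C@@H](O)C[C@@H](/C=C/c2ccc(Cl)cc2Cl)O1` gives 4%, a reading that differs from compound 1 only within the scatter, so none of the three is separated from the others.

The untested compound 4 `CO[C@@H]1C[C@H](O)C[C@@H](/C=C/c2ccc(Cl)cc2Cl)O1` keeps every atom and bond of compound 1; the two differ as follows: the two compounds have the same atoms and bonds and differ only in configuration as drawn: 1 of 4 stereo elements differ; a stereocentre at a saturated ring carbon is drawn R in compound 1 and S in compound 4. Among the measured compounds shown here, no pair among the measured compounds shows the effect of changing a single stereocentre, so there is no measured step to lean on. For the measured compounds named here, since compound 1 and compound 2 already lie at the floor of this assay, and no compound in the set rises clear of the scatter, the step from compound 1 to compound 4 is expected to be no larger than the scatter itself, in either direction, with a number 2 percentage points higher from compound 1 to compound 4 (within the scatter) as the expected change. On that basis compound 4 is estimated to give 2% in this assay, with a range from -5% to 12%.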

Compound 4, a percentage reported as inhibition, at one concentration (the size of the read-out at that concentration, not a potency): 0%
Compound 4: the middle estimate sits 2 percentage points above what was measured; the measured number falls inside the stated range.
By their numbers in this assay, from the lowest: compounds 1, 2, 4 and 3 (each within the scatter of the next).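

Among the compounds shown here, compound 1 and compound 4 give the first single-centre comparison in the set, and in this assay the step reads no change at the digits printed from compound 1 to compound 4 (within the scatter). Changing the stereocentre at this saturated ring carbon from R to S therefore brings no reading clear of the floor at the concentration tested, so neither drawn configuration stands out here. The comparison isolates that one centre, as no other feature changes: the fact that compounds 1 and 4 differ only in the configuration as drawn

From the compounds shown here alone, with both readings at the floor, it remains open whether this configuration would matter in a compound with a clear effect in this assay. Also open, going by these compounds, is whether an ethoxy group or a free hydroxyl in place of the methoxy group, in either configuration, would give a reading clear of the scatter.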